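The source may report more compounds than this note shows. Statements on the series, on what has been measured and on what is new or still open speak of the compounds shown alone.

Values in a functional assay on the whole organism (Hindlimb, strain albino) with Mus musculus as the target, in the maximal electroshock model, with a stated time of 0.5 h; a higher number here means that more compound is needed for the effect, a lower number that less compound is needed:
compound 1 `O=C(/C=C/c1ccc(Cl)cc1)Nc1nc2ccc(Cl)cc2s1`: 204 umol/kg
compound 2 `O=C(/C=C/c1ccccc1)Nc1nc2ccc([N+](=O)[O-])cc2s1`: 485 umol/kg
compound 3 `O=C(/C=C/c1ccccc1)Nc1nc2ccccc2s1`: 646 umol/kg

Compound 3 lies within the scatter of compound 2, and its number is higher than that of compound 1 by more than the scatter. Compound 4 `O=C(/C=C/c1ccccc1)Nc1nc2ccc(Cl)cc2s1` differs from compound 3 by chloro in place of hydrogen on an aromatic carbon. Among the measured compounds shown here, the one measured single-place step is a 1.3-fold higher number from compound 2 to compound 3 (0.12 log units; within the scatter), hydrogen in place of nitro. It involves a different group and says little about chloro. The closer guide is compound 1 at 204 umol/kg, which carries this chloro and a further chloro elsewhere. Its gap to compound 3 spans two changes, and the data do not divide it between them. For the measured compounds named here, only part of that gap is therefore expected for the single change, in the direction of a lower number in this assay. The expected step is a 1.8-fold lower number from compound 3 to compound 4 (0.27 log units; within the scatter). The estimate for compound 4 is 350 umol/kg, with an expected range of 170 umol/kg to 620 umol/kg.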

Compound 4, dose for half-maximal effect: 425 umol/kg
Compound 4: middle estimate off by 1.2-fold (0.08 log units), on the low side; measured number inside the range.
By their numbers in this assay, from the lowest: compound 1; then compounds 4, 2 and 3 (each within the scatter of the next).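

In this assay, chloro at this carbon of the fused system gives a 1.5-fold lower number from compound 3 to compound 4 (0.18 log units; within the scatter) and, set against nitro at the same carbon, a 1.1-fold lower number from compound 2 to compound 4 (0.06 log units; within the scatter) so hydrogen, nitro and chloro at this position are not told apart, as both steps lie within the scatter. Among the compounds shown here, the one single-place step beyond the scatter, though modest, is a 2.1-fold higher number from compound 1 to compound 4 (0.32 log units; beyond the scatter) and it lies at the second chloro of compound 1, not at the position changed here, which places the clearer effect of chloro at that other carbon. No measurement available here accounts for the size of either effect.

Open, going by these compounds, is whether an amine or a methoxy group at the fused-system carbon would give a step beyond the scatter. Also open, on these data alone, is how fluoro or a carboxylic acid would compare with chloro at the place of the second chloro of compound 1.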